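Removing the phenyl hydroxyl from compound 2

This account rests on a few compounds, and the source may have more. Where it says the series, first, only, none or still open, it means among the compounds named here.

Working notes on the cinnamamide series. Compound 2 `CCCc1cc(N)c2cc(NC(=O)/C=C/c3ccc(O)cc3)ccc2n1` carries a 4-hydroxyphenyl group on the acrylamide and, in an assay on isolated protein for displacement of a labelled ligand from melanin-concentrating hormone receptor 1 (Homo sapiens) (a lower number here means a stronger inhibitor, a higher number a weaker inhibitor), compound 2 gives 1100 nM, the highest of the three numbers recorded so far. Compound 1 `CCCc1cc(OC)c2cc(NC(=O)/C=C/c3ccc(C(F)(F)F)cc3)ccc2n1`, with a methoxy-bearing core and a trifluoromethyl on the aryl ring, gives 26 nM in this assay, while compound 3 `CC(C)c1cc(N)c2cc(NC(=O)/C=C/c3ccc(C(F)(F)F)cc3)ccc2n1`, with the amino core, an isopropyl chain and the same trifluoromethyl aryl, gives 2.1 nM. Compound 2 therefore sits well above both of its neighbours, though each of those differs from it in more than one place.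

Compound 4 `CCCc1cc(N)c2cc(NC(=O)/C=C/c3ccccc3)ccc2n1` keeps the amino core and propyl chain of compound 2 and changes only the aryl ring: hydrogen in place of hydroxy on an aromatic carbon. Going by the values given here, no single-change step is available for comparison. The trifluoromethyl analogues compound 1 and compound 3 point to a lower number once the hydroxy is gone, and the step from compound 2 is expected to be a 3.7-fold lower number from compound 2 to compound 4 (0.56 log units; beyond the scatter) in this assay. Compound 4 is estimated at 300 nM, with a plausible range of 60 nM to 1500 nM.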

Compound 4, half-maximal inhibitory concentration: 1000 nM
Beside the measured number, compound 4's estimate is 3.3-fold (0.52 log units) below it; the measured number falls inside the stated range.
By their numbers in this assay, from the lowest: compound 3; then compound 1; then compounds 4 and 2 (each within the scatter of the next).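

With the amino core and propyl chain held constant, the step in this assay is a 1.1-fold lower number from compound 2 to compound 4 (0.04 log units; within the scatter), so exchanging hydroxy for hydrogen at this aromatic carbon, para to a large group, gives no readable change. On this pair, the hydroxy therefore does not account for the high number of compound 2, and compound 4 stands at the same level without it. No measurement in hand gives a reason for this result.

The compounds shown leave open whether a trifluoromethyl at this position would change the number on the propyl and amino background, since compound 1 and compound 3 each differ from compound 4 in more than one place. Also open, as far as these compounds go, is how a nitrile, a carboxylic acid or an amine would read at the same aromatic carbon.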